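The compounds below may be only part of what the source reports. "The series", "measured", "known", "first", "only" and "open" are said of these compounds alone.

Measured so far in a functional assay on SK-N-MC cells (Homo sapiens) for cytotoxicity, read by MTT assay; a lower number here means a stronger inhibitor, a higher number a weaker inhibitor:
compound 1 `COc1cc(/C=C2\CCC/C(=C\c3ccccc3[N+](=O)[O-])C2=O)cc(Br)c1OC` gives 6.24 ug/mL;
compound 2 `COc1cccc(/C=C2\CCC/C(=C\c3cccc([N+](=O)[O-])c3)C2=O)c1` gives 4.94 ug/mL;
compound 3 `COc1cc(/C=C2\CCC/C(=C\c3cccc([N+](=O)[O-])c3)C2=O)cc(Br)c1OC` gives 16.7 ug/mL.

Compound 3 stands highest of the three numbers, with compound 1 nearest to it and compound 2 furthest from it. Compound 4 `CCCOc1c(Br)cc(/C=C2\CCC/C(=C\c3cccc([N+](=O)[O-])c3)C2=O)cc1OC` differs from compound 3 by ethyl in place of hydrogen on a saturated chain carbon bound to an oxygen on an aromatic ring, that is, methoxy to propoxy. Among the compounds with values here, no measured step touches this alkoxy chain: the only step in the set, a 2.7-fold higher number from compound 1 to compound 3 (0.43 log units; beyond the scatter), concerns the nitrophenyl group and carries no information on the change at hand. Within the data shown here, with no bearing step, no shift beyond the scatter is expected, and the expected step is a 1.0-fold lower number from compound 3 to compound 4 (0.02 log units; within the scatter). Compound 4 is therefore estimated at 16 ug/mL, with a range from 7 ug/mL to 36 ug/mL.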

Compound 4, half-maximal inhibitory concentration: 1.51 ug/mL
Compound 4: middle estimate off by 11-fold (1.03 log units), on the high side; the whole stated range lies above it.
By their numbers in this assay, from the lowest: compound 4; then compounds 2 and 1 (each within the scatter of the next); then compound 3.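

In this assay, within the data shown here, going from methoxy to propoxy on the oxygen on the aromatic ring gave an 11-fold lower number from compound 3 to compound 4 (1.04 log units; beyond the scatter), so this alkoxy chain, which the earlier compounds left unchanged, is a place where the number responds strongly. This large step exceeds the modest one seen for moving the nitro group on the nitrophenyl. No measured evidence accounts for the shift. From the compounds shown here alone, whether ethoxy gives part of this step, and whether a longer chain such as butoxy extends it, stays open. So does whether propoxy acts alike on the 2-nitrophenyl compound 1.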